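Swapping the aryl amine for azepane on the pyridine

The source may hold more compounds than are shown below. What is called first, only, known or untested is meant among the compounds shown, and "the series" means these compounds.

Two compounds have been run in a functional assay on CHO-K1 cells for antagonist activity at transient receptor potential cation channel subfamily V member 1 (Homo sapiens), read by FLIPR; a lower number here means a stronger inhibitor, a higher number a weaker inhibitor. Compound 1 `CC(C(=O)NCc1ccc(C(F)(F)F)nc1N(C)c1ccccc1)c1ccc(NS(C)(=O)=O)c(F)c1` gives 0.9 nM in this assay, the higher of the two numbers seen so far. Compound 2 `CC1CCCN1c1nc(C(F)(F)F)ccc1CNC(=O)[C@@H](C)c1ccc(NS(C)(=O)=O)c(F)c1` gives 0.3 nM in this assay, a number that sits beyond the scatter below that of compound 1. Compound 3 `CC(C(=O)NCc1ccc(C(F)(F)F)nc1N1CCCCCC1)c1ccc(NS(C)(=O)=O)c(F)c1` keeps the shared core of compound 1 and changes one group on the aromatic carbon next to the ring nitrogen: azepan-1-yl in place of methyl(phenyl)amino on an aromatic carbon. For the measured compounds named here, no pair of measured compounds differs in just this way, so the size of the step has to be judged from the two numbers alone; compound 2, which also carries a saturated nitrogen ring at that position, gives the lower number. For compound 3 a modest step downward, or none beyond the scatter, is expected, a 1.5-fold lower number from compound 1 to compound 3 (0.18 log units; within the scatter). Compound 3 is therefore estimated at 0.6 nM in this assay, within a range from 0.2 nM to 2 nM.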

Compound 3, inhibition constant: 0.8 nM
The estimate for compound 3 lay 1.3-fold (0.12 log units) below the measured number, and the stated range covers the measured number.
By their numbers in this assay, from the lowest: compound 2; then compounds 3 and 1 (each within the scatter of the next).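

Azepan-1-yl in place of methyl(phenyl)amino, on the aromatic carbon next to the ring nitrogen, gives a 1.1-fold lower number from compound 1 to compound 3 (0.05 log units; within the scatter) in this assay. This single-place step shows that, with the shared core held fixed, the six-membered aromatic ring of carbon in the leaving group is not required at this position for a number of this size: a seven-membered non-aromatic ring takes its place, and compound 1 and compound 3 cannot be told apart. Nothing measured here bears on why the two groups read alike.

The compounds shown leave open how a piperidine, a morpholine or an open-chain dimethylamino group on this same carbon would read in this assay. They also leave open whether a bare hydrogen there would keep a number of this size.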